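The compounds below may be only part of what the source reports. "The series", "measured", "known", "first", "only" and "open" are said of these compounds alone.

Measured in a functional assay on SK-OV-3 cells (Homo sapiens) for cytotoxicity, read by MTT assay, with a stated time of 48 h; a higher number here means a weaker inhibitor, a lower number a stronger inhibitor:
compound 1, `O=C(/C=C/c1ccc2c(c1)B(O)OC2)c1cccs1`, gives 10400 nM
compound 2, `Cn1cccc1C(=O)/C=C/c1ccc2c(c1)B(O)OC2`, gives 93600 nM
compound 3, `O=C(/C=C/c1ccc2c(c1)B(O)OC2)c1ccc(Cl)cc1`, gives 3700 nM

Compound 1 holds the second highest of these three numbers; the nearest step away from it is a 2.8-fold lower number from compound 1 to compound 3 (0.45 log units; beyond the scatter), the furthest is a 9.0-fold higher number from compound 1 to compound 2 (0.95 log units; beyond the scatter). Compound 4, `O=C(/C=C/c1ccc2c(c1)B(O)OC2)c1ccccc1O`, differs from compound 1 in one place: 2-hydroxyphenyl in place of thiophen-2-yl on a carbonyl carbon. The step that bears most on this change is the one where a 4-chlorophenyl took the same place on the carbonyl carbon, giving a 2.8-fold lower number from compound 1 to compound 3 (0.45 log units; beyond the scatter); the exchange for a 1-methyl-1H-pyrrol-2-yl went the other way, a 9.0-fold higher number from compound 1 to compound 2 (0.95 log units; beyond the scatter). A modest downward step in this assay is therefore expected. For compound 4 this means an expected step of a 1.9-fold lower number from compound 1 to compound 4 (0.28 log units; within the scatter). Compound 4 is estimated to give 5500 nM, in the range 1800 nM to 18000 nM.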

Compound 4, half-maximal inhibitory concentration: 48800 nM
Compound 4: middle estimate off by 8.9-fold (0.95 log units), on the low side; the whole stated range lies below it.
By their numbers in this assay, from the lowest: compound 3; then compound 1; then compounds 4 and 2 (each within the scatter of the next).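

Within this assay a six-membered aromatic ring on the carbonyl carbon does not by itself set the result: 2-hydroxyphenyl and 4-chlorophenyl are both such rings, yet they sit far apart (a 13-fold higher number from compound 3 to compound 4 (1.12 log units; beyond the scatter)). Thiophen-2-yl also gives a lower number than 2-hydroxyphenyl (a 4.7-fold higher number from compound 1 to compound 4 (0.67 log units; beyond the scatter)), while compound 4 stays level with the 1-methyl-1H-pyrrol-2-yl compound (a 1.9-fold lower number from compound 2 to compound 4 (0.28 log units; within the scatter)). Nothing available explains these differences. From the compounds shown here alone, what a plain phenyl would give remains open, as does the result of an amine in place of the hydroxyl on that ring.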